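A few compounds are considered here, and "the series" means these few. Any claim that something is new, unique, unknown or untested is made for them only; others in the source may bear on it.

Compound 1 `COc1cc2c(cc1O)O[C@H](c1ccccc1)CC2=O` was tested in a functional assay on HeLa cells (Homo sapiens) for cytotoxicity, read by MTT assay, with a stated time of 72 h (on this read-out lower numbers stand for stronger inhibition and higher numbers for weaker inhibition), where compound 1 gives 5600 nM. For the measured compounds named here, only one other compound has a reading here. Compound 2 `O=C1C[C@@H](c2ccccc2)Oc2cc(O)c(O)c(O)c21` reaches only the boundary of the test: in this assay compound 2 gives > 100000 nM, which is a limit and not a measured number, so no difference between compound 1 and compound 2 can be sized. Compound 1 therefore stands as the only measured number shown, while the other reading sits at the limit of > 100000 nM in this assay, at which 1 of the 2 values shown sits. Compound 3 `COc1cc2c(cc1O)O[C@H](c1ccccc1)[C@@H](O)C2=O` has not yet been tested. It differs from compound 1 in one place: hydroxy in place of hydrogen on a saturated ring carbon. No measured pair differs in exactly this way, so no directly comparable step is known, and nothing shown says whether a hydroxy at such a place helps or hurts. The step expected in this assay is small and is written as a 1.4-fold higher number from compound 1 to compound 3 (0.15 log units; within the scatter), quite possibly not beyond the usual scatter. For compound 3 the estimate in this assay is 8000 nM, within a range from 2500 nM to 30000 nM.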

Compound 3, half-maximal inhibitory concentration: > 100000 nM
Compound 3 ended at the assay's limit; the forecaster's own chance of this, stated with the estimate: 10%; at least 12-fold (1.09 log units) between middle value and limit.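

In this assay, for the compounds shown here, placing a hydroxy on this saturated ring carbon gives an at least 17-fold higher number from compound 1 to compound 3 (1.25 log units; beyond the scatter), so the earlier compounds' silence about this position is now replaced by a clear result: this carbon, next to the ring atom that bears a phenyl group, does not tolerate every change. The change is small, a single oxygen with its hydrogen in place of one hydrogen, yet it is enough to take the core of compound 1 from a measured reading to no measurable reading in this test. The reading of compound 3 is a limit and not a number, so the true size of the step remains unknown, and this reading joins the other one at the edge of the test: the limit of > 100000 nM in this assay, at which 2 of the 3 values shown sit.

The compounds shown leave open whether this loss belongs to the hydroxy itself or would follow from any group at this carbon, and a fluorine, a methoxy or an amine there would help separate those possibilities. They also leave open how much weaker compound 3 really is and what lies behind the change.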